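Swapping a dichlorophenyl for a dimethoxyphenyl on the carbonyl

The source may hold more compounds than are shown below. What is called first, only, known or untested is meant among the compounds shown, and "the series" means these compounds.

Compound 1 `COc1cc(-c2cc(/C=C/C(=O)c3ccc(Cl)c(Cl)c3)[nH]n2)cc(OC)c1OC` is the weakest of the three measured compounds: in a functional assay on A498 cells (Homo sapiens) for inhibition, read by sulforhodamine B assay, with a stated time of 48 h (a lower number here means a stronger inhibitor of growth, a higher number a weaker inhibitor of growth), compound 1 gives 43000 nM, the highest number of the set. Compound 2 `COc1ccc(-c2cc(/C=C/C(=O)c3ccc(N)cc3)[nH]n2)cc1OC` gives 7090 nM, and compound 3 `COc1ccc(-c2cc(/C=C/C(=O)c3cc(OC)c(OC)c(OC)c3)[nH]n2)cc1OC` gives 4990 nM, both well beyond the scatter from compound 1. Compound 4 `COc1ccc(C(=O)/C=C/c2cc(-c3cc(OC)c(OC)c(OC)c3)n[nH]2)cc1OC` keeps the shared core of compound 1 but carries 3,4-dimethoxyphenyl in place of 3,4-dichlorophenyl on a carbonyl carbon. Compound 3, which also has methoxy groups on the ring attached to the carbonyl, gives 4990 nM, so the step from compound 1 is expected to run toward a lower number and beyond the scatter, estimated as a 7.2-fold lower number from compound 1 to compound 4 (0.86 log units; beyond the scatter). Compound 4 is therefore expected to reach about 6000 nM, with a likely range from 2000 nM to 20000 nM.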

Compound 4, concentration for total growth inhibition: 2980 nM
Compound 4: the middle estimate sits 2.0-fold (0.30 log units) above what was measured; the measured number falls inside the stated range.
By their numbers in this assay, from the lowest: compounds 4, 3 and 2 (each within the scatter of the next, the first and the last beyond it); then compound 1.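

Going by these compounds alone, on a carbonyl carbon, 3,4-dimethoxyphenyl in place of 3,4-dichlorophenyl gives a 14-fold lower number from compound 1 to compound 4 (1.16 log units; beyond the scatter) in this assay and this is the first change that can be read alone, since the earlier compounds differ from one another in more than one place. With the rest of compound 1 held fixed, the group on this carbonyl carbon can alone produce a large step. Nothing available here explains why the number falls.

On these data alone, it remains open whether a single methoxy group would match the two in compound 4, and how a nitrile or a carboxylic acid on this ring would compare.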